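Moving the methoxy group: compound 2 to compound 3

The source may hold more compounds than are shown below. What is called first, only, known or untested is meant among the compounds shown, and "the series" means these compounds.

Of the compounds shown here, two sharing one core have been measured in a functional assay on spleen for antagonist activity at Alpha-1B adrenergic receptor (Rattus norvegicus); a lower number here means a less potent compound, a higher number a more potent compound, by a factor of ten per unit of this negative logarithm. Compound 1 `COc1cccc(OC)c1OCCNCCOc1ccccc1OCc1ccc([N+](=O)[O-])cc1` gives 9.02 in this assay, and compound 2 `COc1cccc(COc2ccccc2OCCNCCOc2c(OC)cccc2OC)c1` gives 8.31. Compound 2 thus stands at the lower of the two numbers, with compound 1 above it by a gap beyond the scatter. For the measured compounds named here, the only measured step, a number 0.71 log units lower from compound 1 to compound 2 (beyond the scatter), is the exchange of the 4-nitrophenyl group of compound 1 for the 3-methoxyphenyl group of compound 2.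

Compound 3 `COc1ccc(COc2ccccc2OCCNCCOc2c(OC)cccc2OC)cc1` is the next compound and is not yet measured. It differs from compound 2 in one place: 4-methoxyphenyl in place of 3-methoxyphenyl on a saturated chain carbon bound to an oxygen on an aromatic ring. Going by the values given here, no measured step changes only the position of a methoxy group, so the step from compound 1 to compound 2 bears on this change only loosely, as a sign that the group on that saturated chain carbon matters to this assay. The step in this assay is therefore expected to be small, with direction uncertain, as a number 0.19 log units higher from compound 2 to compound 3 (within the scatter). On that basis compound 3 is estimated at 8.5 in this assay, expected to lie between 7.9 and 9.1.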

Compound 3, negative logarithm of the antagonist equilibrium constant: 9.51
The estimate for compound 3 lay 1.01 log units below the measured number; the whole stated range lies below it.
By their numbers in this assay, from the lowest: compound 2; then compound 1; then compound 3.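

In this assay, moving the methoxy group while keeping exactly the same atoms gives a number 1.20 log units higher from compound 2 to compound 3 (beyond the scatter), so the point at which this group is attached to the phenyl ring matters a great deal, something the earlier pair could not show because its step changed both the group and its attachment point. The exchange of nitro for methoxy on an aromatic carbon gives a number 0.49 log units higher from compound 1 to compound 3 (beyond the scatter), which means the lower number of compound 2 cannot simply be read as the cost of losing the nitro group, since compound 3 also lacks it and still stands highest of the three. Nothing measured here explains why the 4-methoxyphenyl group outperforms the 3-methoxyphenyl group.

These three compounds cannot show whether a plain phenyl group, carrying neither methoxy nor nitro, would fall above or below them, or how an amine or a carboxylic acid in place of the methoxy would fare. Going by these compounds, with only this one receptor assay in view, it also remains open whether the effect of moving the methoxy group carries over to any other adrenergic receptor.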